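The compounds below may be only part of what the source reports. "The series", "measured", "known", "first", "only" and "open" are said of these compounds alone.

Measured so far in a physicochemical assay for solubility, read by mass spectrometry, in phosphate buffer, with a stated time of 24 h, at pH 7.4; on this read-out higher numbers stand for higher solubility and lower numbers for lower solubility:
Compound 1 `O=C(Nc1ccc(C(F)(F)F)cc1)NC1CCN(C(=O)c2ccoc2)CC1` gives 2.2 ug/mL.
Compound 2 `O=C(Nc1ccc(C(F)(F)F)c(F)c1)NC1CCN(C(=O)C2CC2)CC1` gives 0.46 ug/mL.
Compound 3 `O=C(Nc1ccc(C(F)(F)F)cc1)NC1CCN(C(=O)C2CCOCC2)CC1` gives 17.6 ug/mL.

Compound 3 holds the highest number of the three. For the measured compounds named here, the only measured step between two compounds that differ in a single place is an 8.0-fold higher number from compound 1 to compound 3 (0.90 log units; beyond the scatter), which lies beyond the scatter. Compound 4 `O=C(Nc1ccc(C(F)(F)F)c(F)c1)NC1CCN(C(=O)C2CCOCC2)CC1` differs from compound 3 in one place: fluoro in place of hydrogen on an aromatic carbon. Going by the values given here, no measured step covers this change; the step of an 8.0-fold higher number from compound 1 to compound 3 (0.90 log units; beyond the scatter) concerns another part of the molecule and so does not bear on it. Compound 2 carries the same fluoro as compound 4, but it also differs from compound 3 in a second place, so its value, the lowest of the three, can only hint at a direction and cannot fix a size. A modest downward step is expected, a 2.0-fold lower number from compound 3 to compound 4 (0.29 log units; within the scatter), though it may well fall within the scatter. Compound 4 is estimated at 9 ug/mL, with a range from 3 ug/mL to 25 ug/mL.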

Compound 4, solubility: 42 ug/mL
For compound 4 the middle estimate is 4.7-fold (0.67 log units) below the measured one; measured number above the stated range.
By their numbers in this assay, from the lowest: compound 2; then compound 1; then compound 3; then compound 4.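

In this assay, for the compounds shown here, the first reading of the added fluoro, ortho to a trifluoromethyl group, is a 2.4-fold higher number from compound 3 to compound 4 (0.38 log units; beyond the scatter) and so points upward, by a modest step. With that fluoro present in both compounds, oxan-4-yl in place of cyclopropyl on a carbonyl carbon gives a 91-fold higher number from compound 2 to compound 4 (1.96 log units; beyond the scatter) and so is a far larger step, which means the low number of compound 2 gives no reason to read the fluoro as a drawback. No measured evidence here accounts for either step.

From the compounds shown here alone, whether the fluoro step carries over when furan-3-yl or cyclopropyl sits on the carbonyl remains open. So does the effect on the number of chlorine or a methoxy group on the same aromatic carbon.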